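The source may report more compounds than this note shows. Statements on the series, on what has been measured and on what is new or still open speak of the compounds shown alone.

Compound 1 `N#Cc1ccccc1COc1c(-c2ccccc2)oc2cc(O)cc(O)c2c1=O` gives > 100000 nM in an ADME assay on Huh-5-2 cells (Homo sapiens) for cytotoxicity, read by WST assay, with a stated time of 3 days (on this read-out higher numbers stand for lower toxicity in this test and lower numbers for higher toxicity in this test), which is a limit of the test. Compound 2 `N#Cc1cccc(COc2c(-c3ccccc3)oc3cc(O)cc(O)c3c2=O)c1` gives 21000 nM. Compound 3 `Cc1cccc(COc2c(-c3ccccc3)oc3cc(O)cc(O)c3c2=O)c1` gives 29000 nM.

Compound 2 holds the lowest of the two numbers, and its nearest neighbour is compound 3, with a 1.4-fold higher number from compound 2 to compound 3 (0.14 log units; within the scatter). The third value, that of compound 1, is only a limit (the limit of > 100000 nM in this assay, at which 1 of the 3 values shown sits). Compound 4 `Cc1ccc(COc2c(-c3ccccc3)oc3cc(O)cc(O)c3c2=O)cc1` differs from compound 2 by 4-methylphenyl in place of 3-cyanophenyl on a saturated chain carbon bound to an oxygen on an aromatic ring. Of the measured steps, a 1.4-fold higher number from compound 2 to compound 3 (0.14 log units; within the scatter) bears most directly, since it also exchanges cyano for methyl and stayed within the scatter; an at least 4.7-fold lower number from compound 1 to compound 2 (0.67 log units; beyond the scatter) and an at least 3.4-fold lower number from compound 1 to compound 3 (0.53 log units; beyond the scatter) both start from 2-cyanophenyl, not from 3-cyanophenyl. Compound 4 is therefore expected to show no step beyond the scatter, with a 1.3-fold higher number from compound 2 to compound 4 (0.11 log units; within the scatter). Compound 4 is estimated at 27000 nM, between 10000 nM and 75000 nM.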

Compound 4, half-maximal cytotoxic concentration: 40000 nM
The estimate for compound 4 lay 1.5-fold (0.17 log units) below the measured number, within the range that was stated.
By their numbers in this assay, from the lowest: compounds 2, 3 and 4 (each within the scatter of the next). At a limit, above all of these: compound 1.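

In this assay, 4-methylphenyl at the saturated chain carbon bound to an oxygen on an aromatic ring does not separate from the groups already there: a 1.9-fold higher number from compound 2 to compound 4 (0.28 log units; within the scatter) and a 1.4-fold higher number from compound 3 to compound 4 (0.14 log units; within the scatter) both stay within the scatter. Only 2-cyanophenyl stands apart, with an at least 2.5-fold lower number from compound 1 to compound 4 (0.39 log units; beyond the scatter). Compound 1 carries a limit, not a number: the limit of > 100000 nM in this assay, at which 1 of the 4 values shown sits.

The compounds shown leave open how an amine or a carboxylic acid on this phenyl ring would read in this assay, and whether a longer chain in place of the methyl would stay within the scatter.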